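Stretching the amide: a two-carbon linker on compound 1

A few compounds are considered here, and "the series" means these few. Any claim that something is new, unique, unknown or untested is made for them only; others in the source may bear on it.

Compound 1 `Cc1ccc(C(=O)N[C@@H](C(=O)N2CCC(c3ccc(Cl)cc3)CC2)C(C)C)cc1` is the stronger of the two compounds measured in an assay on THP-1 cells for displacement of a labelled ligand from C-C chemokine receptor type 1 (Homo sapiens); a lower number here means a stronger inhibitor, a higher number a weaker inhibitor: compound 1 gives 25 nM, while compound 2 `CC(C)C(NC(=O)c1ccccc1)C(=O)N1CCN(c2ccc(Cl)cc2)CC1` gives 525 nM. The two differ in several places at once, so the comparison shows only the values, not any single cause. Compound 3 `Cc1ccc(CCC(=O)N[C@@H](C(=O)N2CCC(c3ccc(Cl)cc3)CC2)C(C)C)cc1` has not been measured in this assay. It differs from compound 1 in one spot: 2-(4-methylphenyl)ethyl in place of 4-methylphenyl on a carbonyl carbon, so the aromatic ring is moved away from the carbonyl by a short chain. Within the data shown here, no measured pair in this set shows what such a change does here. The expectation is a moderate loss, with the step from compound 1 to compound 3 estimated at a 3.2-fold higher number from compound 1 to compound 3 (0.51 log units; beyond the scatter), and an uncertainty wide enough that no change beyond the scatter is also possible. Compound 3 is therefore estimated at 80 nM, with a range from 20 nM to 400 nM.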

Compound 3, half-maximal inhibitory concentration: 105 nM
The estimate for compound 3 lay 1.3-fold (0.12 log units) below the measured number, within the range that was stated.
By their numbers in this assay, from the lowest: compound 1; then compound 3; then compound 2.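

Among these compounds, replacing 4-methylphenyl with 2-(4-methylphenyl)ethyl on a carbonyl carbon gives a 4.2-fold higher number from compound 1 to compound 3 (0.62 log units; beyond the scatter) in this assay and is the first comparison here that changes only this position. The step is modest, and inhibition weakens without disappearing: compound 3 gives 105 nM and remains a measurable inhibitor, so the aromatic ring can be moved away from the carbonyl at some cost in strength. Nothing measured here explains why the longer group gives the weaker inhibitor.

Among the compounds shown here, only one chain length has been compared so far, so it remains open whether a shorter link, as in 4-methylbenzyl, or a longer chain, as in 3-(4-methylphenyl)propyl, would cost more or less. On these data alone, it is also open how an ether oxygen or an amine placed within the chain would change the number.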